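This account rests on a few compounds, and the source may have more. Where it says the series, first, only, none or still open, it means among the compounds named here.

Compound 1, `OCCNC(=S)Nc1ccccc1`, in a toxicity assay on RAW264.7 cells (Mus musculus) for cytotoxicity, read by MTT assay, with a stated time of 24 h (on this read-out lower numbers stand for higher toxicity in this test and higher numbers for lower toxicity in this test), gives 105000 nM.
Compound 2, `COc1cc(NC(=S)Nc2ccccc2)cc(OC)c1OC`, in this assay gives 154000 nM.
Compound 3, `O=C(NNC(=S)NCc1ccccc1)c1ccccc1`, in this assay gives 42100 nM.

Among these three thiourea-containing compounds, compound 3 carries the lowest number in this assay, and both gaps set it apart from the others: compound 1 lies above it by more than the usual scatter, and compound 2 further still. On the numbers shown, compound 3 is therefore the most toxic of the three in this test, and compound 2 the least.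

The next compound, compound 4, `O=C(NNC(=S)NCc1ccccc1)c1ccncc1`, is built from compound 3 by a single change: pyridin-4-yl in place of phenyl on a carbonyl carbon. The rest of the molecule, the benzyl thiourea joined to the acyl hydrazide, is kept as it stands. Within the data shown here, no measured pair among the three compounds isolates this kind of exchange, so there is no directly comparable step to lean on. An exchange of one six-membered aromatic ring for another of the same size, with one hetero atom and one added hydrogen-bond acceptor, is a modest alteration, and the expectation for compound 4 is a small move, if any, toward a higher number, with a step of a 1.3-fold higher number from compound 3 to compound 4 (0.12 log units; within the scatter) expected, which may well fall within the scatter. Compound 4 is accordingly estimated at 55000 nM, with a range from 25000 nM to 130000 nM.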

Compound 4, half-maximal cytotoxic concentration: 93200 nM
The estimate for compound 4 lay 1.7-fold (0.23 log units) below the measured number; low and high end bracket the measured number.
By their numbers in this assay, from the lowest: compound 3; then compounds 4, 1 and 2 (each within the scatter of the next).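

In this assay, among these compounds, the exchange of phenyl for pyridin-4-yl on a carbonyl carbon gives a 2.2-fold higher number from compound 3 to compound 4 (0.35 log units; beyond the scatter) and is the first change in this set that can be read in one place. With the benzyl thiourea and the acyl hydrazide kept as they stand, the step shows that the group at this position is not indifferent: replacing one ring carbon with a nitrogen, and so adding one hydrogen-bond acceptor, moves the compound toward lower toxicity in this test, by a modest amount but beyond the scatter. No measurement shown here bears on why the number rises.

The compounds shown leave open whether the ring nitrogen must stand where it does in pyridin-4-yl, which pyridin-3-yl or pyridin-2-yl on the same carbonyl carbon would test, and whether a ring of carbon only carrying a methoxy group or a chlorine would move the number in the same direction. They also leave open whether the same exchange would give a similar step with a group other than benzyl on the thiourea, such as phenyl or a simple ethyl chain, since this reading rests on a single pair.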